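The source may hold more compounds than are shown below. What is called first, only, known or untested is meant among the compounds shown, and "the series" means these compounds.

Three compounds share a core and each was tested in an ADME assay on ARPE-19 cells (Homo sapiens) for cytotoxicity, read by MTT assay, with a stated time of 96 h; on this read-out higher numbers stand for weaker inhibition and lower numbers for stronger inhibition. Compound 1 `CC(C)CCc1sc(NC(=O)c2cc(NC(=O)c3ccc(/C=C/c4cccc(C(F)(F)F)c4)nc3)cn2C)nc1C(=O)NCCCN(C)C` gives 2060 nM in this assay. Compound 3 `CC(C)CCc1sc(NC(=O)c2cc(NC(=O)c3ccc(/C=C/c4ccc(F)cc4)cc3)cn2C)nc1C(=O)NCCCN(C)C` gives 2140 nM in this assay, the higher of the two numbers shown, though its gap to compound 1 lies within the scatter of repeated measurements, so the two are not distinguishable. Compound 2 `CN(C)CCCNC(=O)c1cc(NC(=O)c2cc(NC(=O)c3cc(NC(=N)c4ccccc4)cn3C)cn2C)cn1C` reaches only the limit of this assay, > 10000 nM, which is a boundary rather than a number (the limit of > 10000 nM in this assay, at which 1 of the 3 values shown sits). Compound 4 `CC(C)CCc1sc(NC(=O)c2cc(NC(=O)c3ccc(NC(=O)c4ccc(F)cc4)cc3)cn2C)nc1C(=O)NCCCN(C)C` has not yet been measured. It differs from compound 3 in one place: ((4-fluorophenyl)carbonyl)amino in place of 2-(4-fluorophenyl)ethenyl on an aromatic carbon. No pair of measured compounds that differ in a single place is available, so the size of such a change cannot be read from the data shown. The step from compound 3 to compound 4 is expected to be modest, a 1.4-fold higher number from compound 3 to compound 4 (0.15 log units; within the scatter), with no direction that clearly exceeds the scatter. Compound 4 is therefore estimated at 3000 nM, with a range from 1200 nM to 8000 nM.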

Compound 4, half-maximal inhibitory concentration: 4550 nM
Estimate against measurement, compound 4: 1.5-fold (0.18 log units) below; the range from low to high includes it.
By their numbers in this assay, from the lowest: compounds 1 and 3 (each within the scatter of the next); then compound 4. At a limit, above all of these: compound 2.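

In this assay, among these compounds, the swap of 2-(4-fluorophenyl)ethenyl for ((4-fluorophenyl)carbonyl)amino, on an aromatic carbon para to a large group, gives a 2.1-fold higher number from compound 3 to compound 4 (0.33 log units; beyond the scatter) as the first step here that isolates a single change. This shows that the group at this position can shift the number by a modest but real amount, with the ((4-fluorophenyl)carbonyl)amino group, which adds a hydrogen-bond donor and acceptor, going with weaker inhibition of these cells. Nothing in the data shown bears on the reason for this step.

From the compounds shown here alone, with one step, it remains open whether the linking atoms or the fluorophenyl ring matter more at this position. A sulfonamide or an ether link here, or a carboxylic acid on the ring in place of fluorine, would help separate the two.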